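The source may report more compounds than this note shows. Statements on the series, on what has been measured and on what is new or still open speak of the compounds shown alone.

Measured so far in a functional assay on MCF7 cells (Homo sapiens) for inhibition, read by MTT assay, with a stated time of 24 h; a higher number here means a weaker inhibitor, a lower number a stronger inhibitor:
compound 1 `CCOC(=O)C1=Cc2ccccc2OC1(OCc1cn(-c2ccc(F)cc2)nn1)C(F)(F)F` gives 9100 nM
compound 2 `CCOC(=O)C1=Cc2ccccc2OC1(OCc1cc(-c2ccc3ccccc3c2)no1)C(F)(F)F` gives 65400 nM
compound 3 `Cc1ccc(-c2cc(COC3(C(F)(F)F)Oc4ccccc4C=C3C(=O)O)on2)cc1` gives 30100 nM

Compound 1 holds the lowest number of the three. Its gap to compound 3 and the wider gap to compound 2 both lie beyond the scatter, so within this small set compound 1 is the strongest inhibitor. Compound 4 `CCOC(=O)C1=Cc2ccccc2OC1(OCc1cn(-c2ccc(C)cc2)nn1)C(F)(F)F` is not yet measured. It differs from compound 1 in one place: methyl in place of fluoro on an aromatic carbon. The exchange sits on an aromatic carbon of a six-membered aromatic ring of carbon only, on the 4-fluorophenyl that becomes 4-methylphenyl. Among the compounds with values here, no measured pair isolates this exchange, so no step of this kind is known here. The expected step from compound 1 to compound 4 in this assay is small, none beyond the scatter, with no preferred direction. Compound 4 is estimated at 10000 nM, within 4000 nM to 28000 nM, the step of a 1.1-fold higher number from compound 1 to compound 4 (0.04 log units; within the scatter) being an expectation only.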

Compound 4, half-maximal inhibitory concentration: 26700 nM
Compound 4: the middle estimate sits 2.7-fold (0.43 log units) below what was measured, within the range that was stated.
By their numbers in this assay, from the lowest: compound 1; then compounds 4 and 3 (each within the scatter of the next); then compound 2.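

In this assay methyl in place of fluoro gives a 2.9-fold higher number from compound 1 to compound 4 (0.47 log units; beyond the scatter) on this aromatic carbon. A single-atom exchange at this position therefore moves the number beyond the scatter, and the 4-fluorophenyl compares favourably with the 4-methylphenyl. Nothing at hand explains this shift. On these data alone, it remains open where hydrogen, chloro, methoxy or an amine on this carbon would fall relative to fluoro and methyl. As far as these compounds go, it also remains open whether the same exchange gives a similar step with other groups elsewhere on the shared core.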